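The source may hold more compounds than are shown below. What is called first, only, known or untested is meant among the compounds shown, and "the series" means these compounds.

Measured so far:
- compound 1, `CN(C)C(=O)c1cc2cnc(Nc3ccc(S(=O)(=O)NCCCCN=C=S)cc3)nc2n1C1CCCC1`: 72.7%
- compound 2, `CN(C)C(=O)c1cc2cnc(Nc3ccc(C(=O)NCCCCCCCN=C=S)cc3)nc2n1C1CCCC1`: 107%
- compound 3, `CN(C)C(=O)c1cc2cnc(Nc3ccc(C(=O)NCCCCCN=C=S)cc3O)nc2n1C1CCCC1`: 80.7%

These three compounds share one core and were tested in a functional assay on NCI-H1299 cells (Homo sapiens) for inhibition, read by CCK-8 assay, with a stated time of 72 h, tested at 10 uM; on this read-out lower numbers stand for a weaker effect and higher numbers for a stronger effect at the one concentration tested. Compound 1 stands lowest of the three numbers. Its nearest neighbour is compound 3, whose value lies within the usual scatter of compound 1, so no order can be claimed between the two. Compound 2 lies beyond the scatter above compound 1, and its value shows a clearly stronger effect in this assay.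

Compound 4, `CN(C)C(=O)c1cc2cnc(Nc3ccc(NC(=O)CCCCN=C=S)cc3)nc2n1C1CCCC1`, has not been measured. It differs from compound 1 in one place: a group of 10 heavy atoms (6 carbon, 2 nitrogen, 1 oxygen, 1 sulfur; no ring) in place of a group of 11 heavy atoms (5 carbon, 2 nitrogen, 2 oxygen, 2 sulfur; no ring), on an aromatic carbon. The change sits on an aromatic carbon of a six-membered aromatic ring of carbon only, para to a large group. Within the data shown here, no step between measured compounds matches this change, so the size of the step has no direct precedent. Given that compound 2 reaches 107% while compound 1 gives 72.7%, a step upward beyond the scatter is expected from compound 1 to compound 4, estimated as a number 15.3 percentage points higher from compound 1 to compound 4 (beyond the scatter). Compound 4 is expected to give 88%, with a range from 62% to 108%.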

Compound 4, a percentage reported as inhibition, at one concentration (the size of the read-out at that concentration, not a potency): 82.5%
Compound 4: the middle estimate sits 5.5 percentage points above what was measured; the range from low to high includes it.
By their numbers in this assay, from the lowest: compounds 1, 3 and 4 (each within the scatter of the next); then compound 2.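

In this assay, among these compounds, exchanging the group of 11 heavy atoms for the group of 10 heavy atoms on this aromatic carbon, para to a large group, gives a step of a number 9.8 percentage points higher from compound 1 to compound 4 (within the scatter) and so gives the first direct reading at this position. The two groups cannot be told apart at the one concentration tested, although the entering group has 3 hydrogen-bond acceptors in place of 4 and 3 double bonds outside aromatic rings in place of 4, with 1 hydrogen-bond donor in each. Nothing available explains this result.

The compounds shown leave open whether an amine or a carboxylic acid on this aromatic carbon would give a value in the same range. They also leave open whether a longer chain in the group of 10 heavy atoms would move the value beyond the scatter.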